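Chloro for methoxy on the benzyl of compound 3

This account rests on a few compounds, and the source may have more. Where it says the series, first, only, none or still open, it means among the compounds named here.

Among the three compounds measured in a functional assay on MCF7 cells (Homo sapiens) for cytotoxicity (on this read-out lower numbers stand for stronger inhibition and higher numbers for weaker inhibition), compound 3 `COc1ccc(Cn2cc(/C=N\NC(=O)c3c[nH]c4ccc(Br)cc34)c3ccc(F)cc32)cc1` gives 31700 nM and stands second highest of the three numbers. Compound 1 `O=C(N/N=C\c1cn(Cc2ccc(Cl)cc2)c2cc(F)ccc12)c1c[nH]c2ccccc12` gives 6000 nM, and compound 2 `Cn1cc(C(=O)N/N=C\c2cn(Cc3ccc(Cl)cc3)c3cc(F)ccc23)c2ccccc21` gives 90600 nM. Among the measured compounds shown here, the single step between measured compounds that differ in one place is a 15-fold higher number from compound 1 to compound 2 (1.18 log units; beyond the scatter), a change on an aromatic nitrogen that has nothing to do with the benzyl group.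

Compound 4 `O=C(N/N=C\c1cn(Cc2ccc(Cl)cc2)c2cc(F)ccc12)c1c[nH]c2ccc(Br)cc12` differs from compound 3 by chloro in place of methoxy on an aromatic carbon. For the measured compounds named here, no measured step bears on this change, so the expectation leans on the whole set: compound 4 carries the same 4-chlorobenzyl as compound 1, which gives 6000 nM, while compound 3 with the 4-methoxybenzyl gives 31700 nM. Compound 4 is therefore expected to fall between the two, closer to compound 3 than to compound 1. The expected step is a 2.4-fold lower number from compound 3 to compound 4 (0.39 log units; beyond the scatter), a lower number in this assay for compound 4 than for compound 3. For compound 4 the estimate in this assay is 13000 nM, with a range from 4000 nM to 40000 nM.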

Compound 4, half-maximal inhibitory concentration: 8300 nM
Compound 4: middle estimate off by 1.6-fold (0.19 log units), on the high side; low and high end bracket the measured number.
By their numbers in this assay, from the lowest: compounds 1 and 4 (each within the scatter of the next); then compound 3; then compound 2.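

In this assay, among the compounds shown here, the substituent on the benzyl proves to matter: chloro in place of methoxy, on an aromatic carbon para to a large group, gives a 3.8-fold lower number from compound 3 to compound 4 (0.58 log units; beyond the scatter) and is the first reading of this change in the set. Bromo adds little with the 4-chlorobenzyl in place, since the step of a 1.4-fold higher number from compound 1 to compound 4 (0.14 log units; within the scatter) stays inside the usual variation, so the 4-chlorobenzyl compounds with a free aromatic nitrogen hold together at the low end of the numbers. Going the other way, 5-bromo-1H-indol-3-yl in place of 1-methyl-1H-indol-3-yl gives an 11-fold lower number from compound 2 to compound 4 (1.04 log units; beyond the scatter) as a large step, which shows that the high number of compound 2 does not carry over to compound 4 even with bromo present.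

Nothing available explains why chloro and methoxy differ at this place. On these data alone, whether a hydroxyl, an amine or a trifluoromethyl on the same carbon would sit nearer to chloro or to methoxy stays open, as does whether the chloro-for-methoxy step holds without the bromo.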